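Ethyl for Methyl on the Sulfonamide and Cytotoxicity

A few compounds are considered here, and "the series" means these few. Any claim that something is new, unique, unknown or untested is made for them only; others in the source may bear on it.

Measured compounds:
compound 1 `COc1cc(NC(=O)c2ccc(Cl)cc2)ccc1NS(C)(=O)=O`, 70000 nM
compound 2 `COc1cc(NC(=O)c2cccc(C(F)(F)F)c2)ccc1NS(C)(=O)=O`, 84800 nM
compound 3 `CCS(=O)(=O)Nc1ccc(NC(=O)c2ccc(Cl)cc2)cc1OC`, 60100 nM

All three were tested in an ADME assay on RAW264.7 cells (Mus musculus) for cytotoxicity, read by MTT assay, with a stated time of 48 h; on this read-out higher numbers stand for weaker inhibition and lower numbers for stronger inhibition. Compound 1 and compound 3 differ in one place: methyl in place of hydrogen on a saturated chain carbon bound to a sulfonyl sulfur. That change gave a 1.2-fold lower number from compound 1 to compound 3 (0.07 log units; within the scatter), so the two readings are within the usual scatter of each other. Compound 2 carries a trifluoromethyl group in place of the chlorine of compound 1; how the two cores differ is not broken down here, and their values, for compound 1 70000 nM and for compound 2 84800 nM, are within the scatter of each other.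

Compound 4 `CCS(=O)(=O)Nc1ccc(NC(=O)c2cccc(C(F)(F)F)c2)cc1OC` has not yet been measured in this assay. It differs from compound 2 by methyl in place of hydrogen on a saturated chain carbon bound to a sulfonyl sulfur, the same change as from compound 1 to compound 3, at the same place. Because that earlier change gave a 1.2-fold lower number from compound 1 to compound 3 (0.07 log units; within the scatter), the step is expected to be of a similar size: a 1.2-fold lower number from compound 2 to compound 4 (0.07 log units; within the scatter). Compound 4 is therefore estimated to give 72000 nM, likely between 40000 nM and 130000 nM.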

Compound 4, half-maximal inhibitory concentration: 84800 nM
Compound 4: middle estimate off by 1.2-fold (0.07 log units), on the low side, within the range that was stated.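

In this assay, putting methyl in place of hydrogen on a saturated chain carbon bound to a sulfonyl sulfur, which turns methylsulfonyl into ethylsulfonyl, gave no change at the digits printed from compound 2 to compound 4 (within the scatter). Set beside the earlier step, the change reads the same on the core carrying chlorine and on the core carrying trifluoromethyl: the same change on two cores in this assay, a 1.2-fold lower number (0.07 log units; within the scatter) from compound 1 to compound 3 and no change at the digits printed (within the scatter) from compound 2 to compound 4, 1.2-fold (0.07 log units) apart, within the scatter of two such steps. This supports carrying the change between these two cores with little expected movement in the number, but it does not show that the same would hold on any other core, and a small real effect could stay hidden inside the scatter.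

The compounds shown leave open whether a bigger change at this place, such as a propyl or longer chain or a chain ending in an amine or a carboxylic acid, would move the number beyond the scatter. They also leave open how the step from methyl to ethyl behaves on a core carrying another group, such as a nitrile, where these two cores carry chlorine or trifluoromethyl.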